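The compounds below may be only part of what the source reports. "The series", "measured", "known", "first", "only" and "open" are said of these compounds alone.

In an ADME assay on Vero cells (Chlorocebus sabaeus) for cytotoxicity, read by crystal violet staining (a lower number here means that less compound is tolerated, a higher number that more compound is tolerated), compound 1 (`Clc1cccc(/N=N/N2CCCC2)c1`) gives >= 100000 nM, which is a limit of the assay and not a number. Compound 2 (`CN(C)CCCN(/N=N/c1ccc([N+](=O)[O-])cc1)c1ccccc1`) gives a measured value of 40000 nM, but it differs from compound 1 in more than one place and sets no size for a single change. Compound 3 (`c1ccc(/N=N/N2CCCC2)cc1`) has hydrogen in place of chloro on an aromatic carbon of the core of compound 1, meta to a group of 7 heavy atoms: hydrogen in place of chloro on an aromatic carbon. For the measured compounds named here, no measured pair differs in one place, so any expectation rests on this single change and on the limit held by compound 1. The expected step, a number no higher from compound 1 to compound 3 (the limit leaves the size open), is none beyond the scatter, in either direction. In this assay the estimated value for compound 3 is 100000 nM, with an expected range of 45000 nM to 200000 nM.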

Compound 3, half-maximal cytotoxic concentration: > 100000 nM
Compound 3 was reported as a limit (the forecaster's own chance of this, stated with the estimate: 60%); the middle value sits exactly at the limit.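

No step can be read from compound 1 to compound 3 in this assay: both results are limits of the assay and not numbers. The compounds shown leave open what size of change, if any, hydrogen in place of chloro on an aromatic carbon brings to the half-maximal cytotoxic concentration.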